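The compounds below may be only part of what the source reports. "The series", "measured", "known", "first", "only" and "open" are said of these compounds alone.

Compound 1 `CN(C)c1ccc(C(=O)Nc2cccc(NC(=O)COc3ccc4c(c3)NC(=O)CC4)c2)cc1`: > 10000 nM
Compound 2 `O=C(COc1ccc2c(=O)ccoc2c1)Nc1cccc(NC(=O)c2ccccc2)c1`: 120 nM

Going by the values given here, in an assay on isolated protein for inhibition of Rho-associated protein kinase 1 (Homo sapiens), read by scintillation counting, radiometric assay and 33P incorporation, with a stated time of 40 min, in the presence of a further agent that is not named here (a higher number here means a weaker inhibitor, a lower number a stronger inhibitor), compound 2 gives 120 nM, the only plain number among the two measured compounds. Compound 1 gives a limit of the assay rather than a number, > 10000 nM, as the limit of > 10000 nM in this assay, at which 1 of the 2 values shown sits, records. Compound 3 `O=C(COc1ccc2c(=O)ccoc2c1)Nc1cccc(NC(=O)c2cccc([N+](=O)[O-])c2)c1` is not yet measured. It differs from compound 2 by nitro in place of hydrogen on an aromatic carbon. Among the compounds with values here, no step between two measured compounds is available, so the size of this change cannot be read from the data; the step of a 1.3-fold higher number from compound 2 to compound 3 (0.10 log units; within the scatter) is expected to stay within the usual scatter, with no clear direction. Compound 3 is therefore expected near 150 nM, within 50 nM to 500 nM.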

Compound 3, half-maximal inhibitory concentration: 528 nM
The estimate for compound 3 lay 3.5-fold (0.55 log units) below the measured number; the whole stated range lies below it.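

In this assay, going by these compounds alone, the change from phenyl to 3-nitrophenyl gives a 4.4-fold higher number from compound 2 to compound 3 (0.64 log units; beyond the scatter) and is the first measured step between two compounds that differ in one place. It shows that this position on the ring responds to substitution, and that nitro here weakens inhibition while compound 3 still gives a plain number. No available measurement bears on why the number rises. As far as these compounds go, whether a carboxylic acid or a methoxy group at this position would weaken inhibition too stays open. So does whether nitro would have the same effect elsewhere on this ring.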